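Compound 4: same atoms, rejoined, and an expected flat result

This account rests on a few compounds, and the source may have more. Where it says the series, first, only, none or still open, it means among the compounds named here.

Three compounds have been measured in a functional assay on BGC-823 cells (Homo sapiens) for antiproliferative activity, read by MTT assay, tested at 1 uM; on this read-out lower numbers stand for a weaker effect and higher numbers for a stronger effect at the one concentration tested:
Compound 1, `COc1cc(C2=NN(C(C)=O)C(c3cc(OC)c(OC)c(OC)c3)O2)cc(OC)c1OC`, gives -1.8%.
Compound 2, `COc1cc(C(=O)N/N=C/c2c(Cl)cccc2Cl)cc(OC)c1OC`, gives 0.9%.
Compound 3, `COc1cc(C2=NN(C(C)=O)C(c3ccc(C(F)(F)F)cc3)O2)cc(OC)c1OC`, gives 4.2%.

All three numbers sit close to zero, and every pair lies within the scatter of repeated measurements, so none of them can be called more or less active than another. Compound 2 holds the second highest of the three numbers, with compound 1 nearest and compound 3 furthest, both within the scatter. Compound 4, `COc1cc(C(=O)N/N=C/c2cc(Cl)cc(Cl)c2)cc(OC)c1OC`, has not yet been measured; it differs from compound 2 only in how the same atoms are joined: 3,5-dichlorophenyl in place of 2,6-dichlorophenyl on a carbon with a double bond to nitrogen. Because compound 2 gives 0.9% and its neighbours show nothing beyond the scatter, the expected step is none beyond the scatter: a number 1.1 percentage points higher from compound 2 to compound 4 (within the scatter). Compound 4 is therefore estimated at 2%, with a range from -8% to 12%.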

Compound 4, a percentage reported as inhibition, at one concentration (the size of the read-out at that concentration, not a potency): -7.5%
Compound 4: the middle estimate sits 9.5 percentage points above what was measured; the measured number falls inside the stated range.
By their numbers in this assay, from the lowest: compounds 4, 1, 2 and 3 (each within the scatter of the next, the first and the last beyond it).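

Placing 3,5-dichlorophenyl in place of 2,6-dichlorophenyl on a carbon with a double bond to nitrogen gives the first one-place comparison in this assay, with a number 8.4 percentage points lower from compound 2 to compound 4 (within the scatter) as its step. At this position, then, rejoining the same atoms gives no change that can be told from the scatter at the single concentration tested. No other measurement bears on this result. Still open, from the compounds shown here alone, is whether an amine or a carboxylic acid on this aromatic ring, or a longer chain at this place, would give a number beyond the scatter.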